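Aryl swaps on a diaryl urea core in a cell assay

The source may report more compounds than this note shows. Statements on the series, on what has been measured and on what is new or still open speak of the compounds shown alone.

Compound 1 `COc1cc(NC(=O)Nc2cc(Nc3ccc(OC)c(C)c3)ncn2)cc(OC)c1`: 62%
Compound 2 `CCc1cccc(Nc2cc(NC(=O)Nc3cc(OC)cc(OC)c3)ncn2)c1`: 82.1%
Compound 3 `COc1cc(NC(=O)Nc2cc(Nc3cc(C)cc(F)c3)ncn2)cc(OC)c1`: 64.5%

Of the compounds shown here, three have been measured in a functional assay on PC-9 cells (Homo sapiens) for inhibition, read by MTT assay, with a stated time of 48 h, tested at 10 uM; on this read-out higher numbers stand for more inhibition at the one concentration tested (going by the name of the read-out) and lower numbers for less inhibition. Compound 3 `COc1cc(NC(=O)Nc2cc(Nc3cc(C)cc(F)c3)ncn2)cc(OC)c1` stands second highest of the three; its nearest neighbour is compound 1, and the step of a number 2.5 percentage points higher from compound 1 to compound 3 (within the scatter) lies within the scatter, so the two cannot be ordered. Compound 2 is further off, and the step of a number 17.6 percentage points lower from compound 2 to compound 3 (beyond the scatter) is beyond the scatter, as is a number 20.1 percentage points higher from compound 1 to compound 2 (beyond the scatter).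

Compound 4 `COc1cc(NC(=O)Nc2cc(Nc3ccc(F)c(Cl)c3)ncn2)cc(OC)c1` has not yet been measured. It differs from compound 3 in one place: 3-chloro-4-fluorophenyl in place of 3-fluoro-5-methylphenyl on a nitrogen on an aromatic ring. All three measured steps change the same aryl group on the same nitrogen, so all bear on it, yet none of them replaces one halogen-bearing ring by another. Two of the three steps were modest and one was within the scatter, so a step of at most modest size is expected in this assay, with no clear direction.

Compound 4 is therefore expected to give about 63%, in the range 47% to 79%, which means an expected step of a number 1.5 percentage points lower from compound 3 to compound 4 (within the scatter).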

Compound 4, a percentage reported as inhibition, at one concentration (the size of the read-out at that concentration, not a potency): 77.5%
Estimate against measurement, compound 4: 14.5 percentage points below, within the range that was stated.
By their numbers in this assay, from the lowest: compounds 1 and 3 (each within the scatter of the next); then compounds 4 and 2 (each within the scatter of the next).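

Among these compounds, on the nitrogen on an aromatic ring, the change from 3-fluoro-5-methylphenyl to 3-chloro-4-fluorophenyl is the first step between two halogen-bearing rings, and in this assay it gives a number 13 percentage points higher from compound 3 to compound 4 (beyond the scatter), so carrying a halogen does not by itself fix the number at this position. The 3-chloro-4-fluorophenyl group also gives a number 15.5 percentage points higher from compound 1 to compound 4 (beyond the scatter) when it takes the place of 4-methoxy-3-methylphenyl, whereas against 3-ethylphenyl it gives a number 4.6 percentage points lower from compound 2 to compound 4 (within the scatter), so these last two groups cannot be ordered and 3-ethylphenyl is no longer alone at the upper level of this small set. Nothing available here accounts for these differences.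

The compounds shown leave open which of the two halogens of the 3-chloro-4-fluorophenyl group goes with the higher number, as no ring carrying only the chlorine or only the fluorine in those places appears among them. They also leave open how this position responds to a ring carrying an amine, a carboxylic acid or a chain longer than ethyl, and whether the order seen at this one concentration would hold for potency.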